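Moving the fluorine on the pendant ring of compound 2

A few compounds are considered here, and "the series" means these few. Any claim that something is new, unique, unknown or untested is made for them only; others in the source may bear on it.

Compound 1 `O=S(=O)(c1cc(Cl)cc(Cl)c1)c1cnc2cc(F)ccc2c1-c1ccc(F)cc1` and compound 2 `Cc1ccc(S(=O)(=O)c2cnc3cc(F)ccc3c2-c2cccc(F)c2)cc1F` were both tested in an ADME assay on microsomes from liver (Homo sapiens) for metabolic stability, tested at 2.5 uM; a higher number here means faster removal of the compound, a lower number slower removal. Compound 1 gives 0.18 mL/min. Compound 2 gives 0.41 mL/min, the higher of the two numbers, and the gap to compound 1 is beyond the usual scatter. The two compounds differ in more than one place, so their values alone say nothing about any single change.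

Compound 3 `Cc1ccc(S(=O)(=O)c2cnc3cc(F)ccc3c2-c2ccc(F)cc2)cc1F` has not yet been measured. It differs from compound 2 in one place: 4-fluorophenyl in place of 3-fluorophenyl on an aromatic carbon

For the measured compounds named here, no measured pair shows this change on its own, so its effect is unknown here. The expectation is a small step, likely within the scatter, from compound 2 to compound 3 in this assay, a 1.2-fold lower number from compound 2 to compound 3 (0.09 log units; within the scatter), perhaps slightly downward. Compound 3 is estimated at 0.33 mL/min, with a likely range from 0.15 mL/min to 0.7 mL/min.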

Compound 3, intrinsic clearance in a liver preparation (reported as CLH), per the amount of preparation that the assay uses: 2.33 mL/min
Compound 3: the middle estimate sits 7.1-fold (0.85 log units) below what was measured, and the stated range ends below it.
By their numbers in this assay, from the lowest: compound 1; then compound 2; then compound 3.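

In this assay, 4-fluorophenyl in place of 3-fluorophenyl gives a 5.7-fold higher number from compound 2 to compound 3 (0.75 log units; beyond the scatter) even though the two compounds have the same atoms, so at this position the number depends on how the fluorophenyl group is joined, and not only on which atoms are present. With 4-fluorophenyl held constant, 3-fluoro-4-methylphenyl in place of 3,5-dichlorophenyl on the sulfonyl sulfur gives a 13-fold higher number from compound 1 to compound 3 (1.11 log units; beyond the scatter) in this assay, which isolates a change that compounds 1 and 2 could not separate. Nothing available here explains either step.

Going by these compounds, it remains open how a plain phenyl or a methoxyphenyl would behave at this position. It is also unclear whether moving the fluorine would have a similar effect with 3,5-dichlorophenyl on the sulfonyl sulfur.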